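The compounds below may be only part of what the source reports. "The series", "measured", "known", "first", "only" and "open" are said of these compounds alone.

Measured compounds:
compound 1, `CCc1ccc(S(=O)(=O)NC(=O)Nc2ccc(Cl)cc2)s1`, 89%
compound 2, `CCCc1ccc(S(=O)(=O)NC(=O)Nc2ccc(Cl)cc2)s1`, 39%

Both compounds were tested in a functional assay on the whole organism (6C3HED cells, Mus musculus) for inhibition, at a dose of 300 mg/kg by the oral route; on this read-out higher numbers stand for more inhibition at the one dose given (going by the name of the read-out) and lower numbers for less inhibition. Compound 1 gives 89%, while compound 2 gives 39%. On these two numbers compound 2 stands lowest; its nearest neighbour is compound 1, and the gap a number 50 percentage points lower from compound 1 to compound 2 (beyond the scatter) is large and lies beyond the usual scatter of repeated measurements. That gap goes with a methyl in place of hydrogen on a saturated chain carbon, two bonds along the chain from an aromatic carbon.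

Compound 3, `CC(C)c1ccc(S(=O)(=O)NC(=O)Nc2ccc(Cl)cc2)s1`, has not yet been measured. It differs from compound 2 by isopropyl in place of propyl on an aromatic carbon; the two share the same atoms, joined differently. Within the data shown here, no measured step shows what moving from propyl to isopropyl does in this assay. Among the measured compounds shown here, the only step that can guide an expectation is the large drop from compound 1 to compound 2, which came with a longer chain. Since isopropyl is shorter along its chain than propyl but carries the same count of carbon atoms, the estimate for compound 3 is placed between the two measured values, with a wide range, and the expected change from compound 2 is a number 16 percentage points higher from compound 2 to compound 3 (beyond the scatter). Compound 3 is therefore expected to give about 55%, plausibly anywhere from 25% to 85%.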

Compound 3, a percentage reported as inhibition, in the whole organism at one dose (the size of the read-out at that dose, not a potency): 63%
For compound 3 the middle estimate is 8 percentage points below the measured one, within the range that was stated.
By their numbers in this assay, from the lowest: compound 2; then compound 3; then compound 1.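

The result shows that on this aromatic carbon, the shape of the group matters and not only its size: propyl and isopropyl have the same atoms, yet swapping one for the other in this assay gives a number 24 percentage points higher from compound 2 to compound 3 (beyond the scatter). It also shows that adding a methyl to the ethyl group of compound 1 at the carbon bound to the ring gives a number 26 percentage points lower from compound 1 to compound 3 (beyond the scatter), so among these compounds both ways of adding a carbon to ethyl go with less inhibition, and no compound shown goes against this. Nothing measured here explains why the two arrangements differ.

The compounds shown leave open how a methyl, a cyclopropyl ring, a longer chain or an amine on this aromatic carbon would behave, so it remains unknown whether ethyl is close to the best group there. Each number also comes from one oral dose, so these compounds show the size of the effect at that dose and not how it would change at other doses.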